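Adding an Acetyl Group to a Ring Hydroxy: Cytotoxicity

The source may hold more compounds than are shown below. What is called first, only, known or untested is meant among the compounds shown, and "the series" means these compounds.

Four related compounds are compared for their effect on cancer cell growth. Compound 1 `CCCC[C@H](O)/C=C\[C@@H]1OC(=O)C=C[C@@H]1OC(C)=O`, compound 2 `CCCC[C@H](O)/C=C\[C@@H]1OC(=O)C=C[C@@H]1O` and compound 3 `CCCC[C@H](/C=C\[C@@H]1OC(=O)C=C[C@@H]1O)OC(C)=O` have been measured; compound 4 `CCCC[C@H](/C=C\[C@@H]1OC(=O)C=C[C@@H]1OC(C)=O)OC(C)=O` has not. In a functional assay on HCT-15 cells (Homo sapiens) for cytotoxicity, read by sulforhodamine B assay, with a stated time of 48 h (on this read-out lower numbers stand for stronger inhibition and higher numbers for weaker inhibition), compound 1 gives 5200 nM, compound 2 gives 7400 nM and compound 3 gives 9500 nM. All three numbers lie close together, so none can be ranked against the others.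

Compound 2 and compound 1 differ in one place: acetyl in place of hydrogen on an oxygen on a saturated carbon. This change gave a 1.4-fold lower number from compound 2 to compound 1 (0.15 log units; within the scatter), too small to count as a real shift. The same change, at the same place, turns compound 3 into compound 4: acetyl in place of hydrogen on an oxygen on a saturated carbon. How the core of compound 3 differs from the core of compound 2 is not broken down here.

Among the compounds with values here, the earlier step of a 1.4-fold lower number from compound 2 to compound 1 (0.15 log units; within the scatter) is the only guide to the size of the new one. On that basis the expected step is a 1.4-fold lower number from compound 3 to compound 4 (0.15 log units; within the scatter). Compound 4 is thus estimated at 6800 nM in this assay, with a range between 3500 nM and 13000 nM.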

Compound 4, half-maximal inhibitory concentration: 800 nM
The estimate for compound 4 lay 8.5-fold (0.93 log units) above the measured number, and the stated range ends above it.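

In this assay, placing an acetyl group on an oxygen on a saturated carbon gave a large step, a 12-fold lower number from compound 3 to compound 4 (1.07 log units; beyond the scatter), whereas the same change on the other core stayed within the scatter. The size of this step therefore did not carry over from one core to the other: the same change on two cores in this assay, a 1.4-fold lower number (0.15 log units; within the scatter) from compound 2 to compound 1 and a 12-fold lower number (1.07 log units; beyond the scatter) from compound 3 to compound 4, 8.3-fold (0.92 log units) apart, beyond the scatter of two such steps

This shows that, for these compounds, a step measured on one core can be a poor guide to the same change on another, so a hydroxy to acetoxy swap cannot be assumed to have a fixed effect here. It does not explain the gap, and two pairs of compounds give no rule for any further core.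

On the oxygens that vary, the compounds shown carry only hydrogen or acetyl. As far as these compounds go, it remains open whether a longer chain such as butanoyl, a methyl ether or an amine in place of the oxygen would give a large step, a small one or none.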